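The source may hold more compounds than are shown below. What is called first, only, known or untested is meant among the compounds shown, and "the series" means these compounds.

Measured in a functional assay on THP-1 cells (Homo sapiens) for inhibition, read by ELISA, with stated times of 30 min and 24 h, tested at 10 uM; on this read-out lower numbers stand for a weaker effect and higher numbers for a stronger effect at the one concentration tested:
compound 1 `COc1cc(OC)c(C(=O)c2ccccc2F)c(O)c1CN1CCCC1` gives 87%
compound 2 `COc1cc(O)c(C(=O)c2cccc(Cl)c2)c(OC)c1` gives 78%
compound 3 `COc1cc(OC)c(C(=O)c2cccc(Cl)c2)c(O)c1CN1CCCC1` gives 81%

Compound 1 has the highest number of the three, but its gaps to compound 3 and to compound 2 are within the scatter, so no order among them can be claimed. Compound 3 and compound 1 share a core apart from the group on the carbonyl carbon; the difference is 2-fluorophenyl in place of 3-chlorophenyl on a carbonyl carbon, and the step is a number 6 percentage points lower from compound 1 to compound 3 (within the scatter).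

The change of interest is hydrogen in place of (pyrrolidin-1-yl)methyl on an aromatic carbon, which gives a number 3 percentage points lower from compound 3 to compound 2 (within the scatter). Compound 4 `COc1cc(O)c(C(=O)c2ccccc2F)c(OC)c1` is not yet measured; it arises from compound 1 by hydrogen in place of (pyrrolidin-1-yl)methyl on an aromatic carbon, which is the same change at the same place, made once before and once here. Going by the values given here, because the only precedent is the step of a number 3 percentage points lower from compound 3 to compound 2 (within the scatter), a step of similar size is expected from compound 1 to compound 4, estimated as a number 4 percentage points lower from compound 1 to compound 4 (within the scatter). For compound 4 in this assay the expected read-out is 83%, with an estimated range from 70% to 93%.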

Compound 4, a percentage reported as activity, at one concentration (the size of the read-out at that concentration, not a potency): 71%
For compound 4 the middle estimate is 12 percentage points above the measured one; the range from low to high includes it.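

In this assay, hydrogen in place of (pyrrolidin-1-yl)methyl on the core of compound 1 gives a number 16 percentage points lower from compound 1 to compound 4 (beyond the scatter). Set beside the same change on the core of compound 3, this step cannot be told apart from the earlier one, so the two cores give no sign that the core alters the outcome of the change: the same change on two cores in this assay, a number 3 percentage points lower (within the scatter) from compound 3 to compound 2 and a number 16 percentage points lower (beyond the scatter) from compound 1 to compound 4, 13 percentage points apart, within the scatter of two such steps With only two pairs, this does not establish a single step size that carries to other cores, nor does one step lying beyond the scatter and the other within it show a dependence on the core.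

Open, as far as these compounds go, is whether another amine on the same aromatic carbon, such as morpholin-4-ylmethyl or dimethylaminomethyl, would read like (pyrrolidin-1-yl)methyl or like hydrogen. Also open, from the compounds shown here alone, is how the change behaves with groups on the carbonyl carbon other than 2-fluorophenyl and 3-chlorophenyl, for example unsubstituted phenyl or a phenyl bearing a carboxylic acid.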